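A Halogen Swap on the Benzylamine Arm

The compounds below may be only part of what the source reports. "The series", "measured", "known", "first", "only" and "open" are said of these compounds alone.

compound 1, `Nc1cc(N)c2nc(-c3ccccc3)c(NCc3ccc(Cl)c(Cl)c3)nc2c1`: 6030 nM
compound 2, `COc1cc(CNc2nc3cc(N)cc(N)c3nc2-c2ccccc2)cc(OC)c1OC`: 8710 nM
compound 3, `CCOC(=O)[C@H](CCC(=O)O)NC(=O)c1ccc(Oc2nc3cc(N)cc(N)c3nc2-c2ccccc2)cc1`: 8710 nM

Of the compounds shown here, three built on the same core have been measured in a functional assay on SN12C cells (Homo sapiens) for inhibition, read by sulforhodamine B assay, with a stated time of 48 h; on this read-out higher numbers stand for weaker inhibition of growth and lower numbers for stronger inhibition of growth. Compound 1 gives 6030 nM, the lowest of the three numbers, but compound 2 with 8710 nM and compound 3 with 8710 nM both lie within the usual scatter of that figure, so no order among the three can be read from these values.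

Compound 4, `Nc1cc(N)c2nc(-c3ccccc3)c(NCc3ccc(F)cc3)nc2c1`, has not yet been measured. It differs from compound 1 in a single place: 4-fluorophenyl in place of 3,4-dichlorophenyl on a saturated chain carbon bound to a nitrogen on an aromatic ring. Among the measured compounds shown here, no measured pair in this set shows a change of this kind, so there is no measured step to lean on, and the series gives no sign that substitution on that ring moves the number much either way.

The step of a 1.3-fold higher number from compound 1 to compound 4 (0.12 log units; within the scatter) is therefore expected to stay small, at most a modest move toward a higher number, and is not expected to exceed the scatter clearly. Compound 4 is estimated at 8000 nM, with a range from 3000 nM to 22000 nM.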

Compound 4, concentration for 50% growth inhibition: 7590 nM
For compound 4 the middle estimate is 1.1-fold (0.02 log units) above the measured one, within the range that was stated.
By their numbers in this assay, from the lowest: compounds 1, 4, 2 and 3 (each within the scatter of the next).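

In this assay the swap at this place reads as a 1.3-fold higher number from compound 1 to compound 4 (0.10 log units; within the scatter) and gives the set its first comparison of compounds that differ in one place. Among the compounds shown here, on a saturated chain carbon bound to a nitrogen on an aromatic ring, 4-fluorophenyl and 3,4-dichlorophenyl therefore cannot be told apart on this read-out, which the earlier compounds, with no such pair among them, could not show. Nothing measured here bears on why the two groups read alike.

For the compounds shown here, this single pair covers only two halogen-bearing phenyl groups, so it says nothing about how far the position tolerates change in general. On these data alone, whether an unsubstituted phenyl, a methoxy-bearing ring, or a group of another kind at this place, such as an amine or a carboxylic acid, would give a step beyond the scatter remains open.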